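A few compounds are considered here, and "the series" means these few. Any claim that something is new, unique, unknown or untested is made for them only; others in the source may bear on it.

Measured compounds in a functional assay on HGC-27 cells (Homo sapiens) for cytotoxicity, read by MTT assay, with a stated time of 72 h; a higher number here means a weaker inhibitor, a lower number a stronger inhibitor:

compound 1, `CCCCCCCCNc1nc(SCc2ccc(C(F)(F)F)cc2)nc2ccccc12`: 13400 nM
compound 2, `FC(F)(F)c1ccc(CSc2nc(Nc3ccccc3Cl)c3ccccc3n2)cc1`: > 50000 nM
compound 3, `FC(F)(F)c1ccc(CSc2nc(Nc3cccc(C(F)(F)F)c3)c3ccccc3n2)cc1`: 11700 nM.

The value of compound 2 is a limit of this assay and not a number (the limit of > 50000 nM in this assay, at which 1 of the 3 values shown sits). Among the two numbers, compound 1 gives the highest; compound 3 sits within the scatter of it, so the two cannot be ordered.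

Compound 4, `O=[N+]([O-])c1ccc(Nc2nc(SCc3ccc(C(F)(F)F)cc3)nc3ccccc23)cc1`, has not yet been measured in this assay. It differs from compound 1 in one place: 4-nitrophenyl in place of octyl on a nitrogen on an aromatic ring. Two measured steps make the same kind of exchange at that nitrogen. One, an at least 3.7-fold higher number from compound 1 to compound 2 (0.57 log units; beyond the scatter), went beyond the scatter toward a weaker compound. The other, a 1.1-fold lower number from compound 1 to compound 3 (0.06 log units; within the scatter), stayed within it. Between the two aryl groups themselves, an at least 4.2-fold lower number from compound 2 to compound 3 (0.63 log units; beyond the scatter). The measured aryl groups therefore give no single direction for putting an aryl group in place of octyl; one gave a clear loss, the other no change.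

For compound 4 the expected outcome is a number near that of compound 1 or higher, with a step of a 1.3-fold higher number from compound 1 to compound 4 (0.13 log units; within the scatter), because the two aryl steps an at least 3.7-fold higher number from compound 1 to compound 2 (0.57 log units; beyond the scatter) and a 1.1-fold lower number from compound 1 to compound 3 (0.06 log units; within the scatter) bracket no change and a loss. The estimate for compound 4 is 18000 nM, between 5000 nM and 50000 nM.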

Compound 4, half-maximal inhibitory concentration: 16600 nM
The estimate for compound 4 lay 1.1-fold (0.04 log units) above the measured number; low and high end bracket the measured number.
By their numbers in this assay, from the lowest: compounds 3, 1 and 4 (each within the scatter of the next). At a limit, above all of these: compound 2.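

In this assay, 4-nitrophenyl in place of octyl on this nitrogen gives a 1.2-fold higher number from compound 1 to compound 4 (0.09 log units; within the scatter), so a second aryl group now matches octyl alongside 3-(trifluoromethyl)phenyl, and a 1.4-fold higher number from compound 3 to compound 4 (0.15 log units; within the scatter) leaves these two aryl groups unordered. Compound 2, with 2-chlorophenyl, is now the one aryl compound shown that goes against this pattern, with an at least 3.0-fold lower number from compound 2 to compound 4 (0.47 log units; beyond the scatter). The value of compound 2 is a limit and not a number: the limit of > 50000 nM in this assay, at which 1 of the 4 values shown sits.

The compounds shown leave open whether the loss in compound 2 belongs to the chlorine itself or to where it sits on the ring; a 4-chlorophenyl or a 2-(trifluoromethyl)phenyl group on this nitrogen would separate the two. They also leave open whether any group here can bring the number well below those of compound 1, compound 3 and compound 4, for example a benzyl group, a shorter alkyl chain or a phenyl ring carrying a carboxylic acid.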